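The compounds below may be only part of what the source reports. "The series", "measured", "known", "first", "only" and "open" are said of these compounds alone.

Measured so far in a functional assay on NCI-H460 cells (Homo sapiens) for positive allosteric modulation, read by MTT assay, with stated times of 2 h and 72 h, tested at 1 uM; a lower number here means a stronger inhibitor, a higher number a weaker inhibitor:
- compound 1 `COc1ccc(C(=O)Nc2ccccc2-c2nnn(-c3ccc(OC)cc3)n2)cc1`: 305 nM
- compound 2 `CCCc1ccc(C(=O)Nc2ccccc2-c2nnn(-c3cccc(OC)c3)n2)cc1`: 207 nM

In this assay compound 2 stands at 207 nM, within the scatter of compound 1 at 305 nM, so these two values do not separate. Compound 3 `COc1cccc(-n2nnc(-c3ccccc3NC(=O)c3ccc(N)cc3)n2)c1` carries amino in place of propyl on an aromatic carbon, para to a large group: amino in place of propyl on an aromatic carbon. Within the data shown here, no measured step isolates this change, so the expectation rests on those two values alone. A modest change toward a weaker inhibitor is expected, as the estimated 1.9-fold higher number from compound 2 to compound 3 (0.29 log units; within the scatter). For compound 3 the estimate is 400 nM, with an expected range of 120 nM to 1400 nM.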

Compound 3, half-maximal inhibitory concentration: 217 nM
Compound 3: the middle estimate sits 1.8-fold (0.27 log units) above what was measured; the range from low to high includes it.
By their numbers in this assay, from the lowest: compounds 2, 3 and 1 (each within the scatter of the next).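

In this assay, going from 4-propylphenyl to 4-aminophenyl gives a 1.0-fold higher number from compound 2 to compound 3 (0.02 log units; within the scatter), so at this position the value does not separate when a three-carbon chain with no hydrogen-bond donor is exchanged for amino, which has one. The readout therefore does not distinguish these two groups at this position. No available evidence bears on this result.

As far as these compounds go, it remains open whether a carboxylic acid, a dimethylamino group or a longer chain here would read apart from propyl and amino. The compounds shown contain no step beyond the scatter at this position.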